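This account rests on a few compounds, and the source may have more. Where it says the series, first, only, none or still open, it means among the compounds named here.

Measured in a functional assay on SK-BR-3 cells (Homo sapiens) for antiproliferative activity, read by MTT assay, with a stated time of 48 h; on this read-out lower numbers stand for stronger inhibition and higher numbers for weaker inhibition:

Compound 1, `COc1ccc(C(=O)Nc2ccc(N(C)S(C)(=O)=O)c(OCc3cc(Cl)ccc3Cl)c2)cc1`, gives 490 nM.
Compound 2, `COc1ccc(C(=O)Nc2ccc(N(C)S(C)(=O)=O)c(OCc3cc(Cl)ccc3Cl)c2)cc1OC`, gives 3730 nM.
Compound 3, `COc1ccc(C(=O)Nc2ccc(N(C)S(=O)(=O)C(F)(F)F)c(OCc3cc(C)ccc3C)c2)cc1`, gives 5320 nM.

Compound 1 and compound 2 share one core and differ only by methoxy in place of hydrogen on an aromatic carbon. That change produced a 7.6-fold higher number from compound 1 to compound 2 (0.88 log units; beyond the scatter), a step beyond the usual scatter. Compound 3 is built on a different core; it differs from compound 1 in more than one place, and the difference between the two cores is not broken down here. Compound 3 stands at the highest of the three numbers, while its gap to compound 2 lies within the scatter.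

Compound 4, `COc1ccc(C(=O)Nc2ccc(N(C)S(=O)(=O)C(F)(F)F)c(OCc3cc(C)ccc3C)c2)cc1OC`, is not yet measured. It differs from compound 3 by methoxy in place of hydrogen on an aromatic carbon, the same change that was made from compound 1 to compound 2, at the same kind of place. On the strength of that single earlier step, a 7.6-fold higher number from compound 1 to compound 2 (0.88 log units; beyond the scatter), compound 4 is expected to give a higher number than compound 3, by an estimated 4.7-fold higher number from compound 3 to compound 4 (0.67 log units; beyond the scatter). Compound 3 already gives 5320 nM, which is the highest of the three measured numbers, so compound 4 is expected to lie at the weak end of this assay's range. The estimate for compound 4 in this assay is 25000 nM, with a likely range from 8000 nM to 80000 nM.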

Compound 4, half-maximal inhibitory concentration: 39300 nM
Beside the measured number, compound 4's estimate is 1.6-fold (0.20 log units) below it; the range from low to high includes it.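

In this assay, going from 4-methoxyphenyl to 3,4-dimethoxyphenyl on the carbonyl gave a 7.4-fold higher number from compound 3 to compound 4 (0.87 log units; beyond the scatter), so the added methoxy weakened inhibition on this core too. Set beside the earlier step, the change carried over from one core to the other in the same direction and at about the same size: the same change on two cores in this assay, a 7.6-fold higher number (0.88 log units; beyond the scatter) from compound 1 to compound 2 and a 7.4-fold higher number (0.87 log units; beyond the scatter) from compound 3 to compound 4, 1.0-fold (0.01 log units) apart, within the scatter of two such steps

Within the data shown here, this is only one pair of steps on two cores that differ from each other in more than one place, so it shows that the change held on these two cores, not that it would hold on every core, and it does not show why the added methoxy weakens inhibition.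

The compounds shown leave open how a hydroxyl, a fluorine or an amine would fare in place of the added methoxy. They also leave open how much each separate difference between the two cores contributes on its own.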